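The source may report more compounds than this note shows. Statements on the series, on what has been measured and on what is new or still open speak of the compounds shown alone.

Two compounds of this series have numbers in an assay on membranes from HeLa cells for displacement of a labelled ligand from adenosine receptor A3 (Homo sapiens), read by scintillation counting, with a stated time of 180 min, tested at 1 uM; a lower number here means less inhibition, a higher number more inhibition at the concentration tested (going by the name of the read-out). Compound 1 `CC1=C(C(=O)CC(C)C)C(c2ccoc2)NC(=O)N1` gives 18%. Compound 2 `CC1=C(C(=O)NC(C)C)C(c2ccco2)NC(=O)N1` gives 4%, the lowest of the two, and its gap to compound 1 lies beyond the usual scatter; the two differ in more than one place, so only the two values are known. Compound 3 `CC1=C(C(=O)NC(C)C)C(c2ccoc2)NC(=O)N1` has the same atoms as compound 2 joined differently: furan-3-yl in place of furan-2-yl on a saturated ring carbon. Among the compounds with values here, no single-point step of this kind has been measured here, so the expected step of a number 6 percentage points higher from compound 2 to compound 3 (within the scatter) is small, upward at most and possibly within the scatter. Compound 3 is estimated at 10%, between 0% and 25%.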

Compound 3, a percentage reported as inhibition, at one concentration (the size of the read-out at that concentration, not a potency): 3%
Compound 3: the middle estimate sits 7 percentage points above what was measured, and the stated range covers the measured number.
By their numbers in this assay, from the lowest: compounds 3 and 2 (each within the scatter of the next); then compound 1.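

In this assay, furan-3-yl in place of furan-2-yl on the saturated ring carbon gives a number 1 percentage points lower from compound 2 to compound 3 (within the scatter) and so does not separate the two isopropylcarbamoyl compounds at this position. Within the data shown here, with furan-3-yl held constant, isopropylamino in place of isobutyl on the carbonyl carbon gives a number 15 percentage points lower from compound 1 to compound 3 (beyond the scatter) and is the first single-place change to exceed the scatter. No measurement here bears on the cause of either step.

Going by these compounds, whether a thiophene or phenyl ring on the saturated ring carbon would change the reading remains open. So does the effect of a longer alkyl chain on the carbonyl carbon.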